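The source may report more compounds than this note shows. Statements on the series, on what has been measured and on what is new or still open speak of the compounds shown alone.

Compound 3 `CC1(C)O[C@@H](CO)[C@H](Cn2cc(Cn3c4c(c5ccccc53)C(=O)c3c[n+]([O-])c5ccccc5c3C4=O)nn2)O1` gives 370 nM in a functional assay on A549 cells (Homo sapiens) for cytotoxicity, read by MTT assay, with a stated time of 72 h; a higher number here means a weaker inhibitor, a lower number a stronger inhibitor. Compound 1 `CN1CCN(CCCCCCn2c3c(c4ccccc42)C(=O)c2c[n+]([O-])c4ccccc4c2C3=O)CC1` gives 330 nM in this assay, and compound 2 `O=C1c2c[n+]([O-])c3ccccc3c2C(=O)c2c1c1ccccc1n2Cc1cn(C[C@@H](O)CO)nn1` gives 390 nM. Compound 3 thus stands second highest of the three numbers, nearest compound 2 and furthest from compound 1, with both gaps within the scatter. Compound 4 `O=C1c2c[n+]([O-])c3ccccc3c2C(=O)c2c1c1ccccc1n2Cc1cn([C@@H]2C[C@H](O)[C@@H](CO)O2)nn1` differs from compound 3 by 4-hydroxy-5-(hydroxymethyl)oxolan-2-yl in place of (5-(hydroxymethyl)-2,2-dimethyl-1,3-dioxolan-4-yl)methyl on an aromatic nitrogen. The two measured steps, a 1.2-fold higher number from compound 1 to compound 2 (0.07 log units; within the scatter) and a 1.1-fold lower number from compound 2 to compound 3 (0.02 log units; within the scatter), each exchanged the side chain carried by the shared core and each stayed within the scatter. The change to compound 4 again exchanges only that side chain, so no step beyond the scatter is expected in this assay. Compound 4 is therefore expected to give about 370 nM, between 200 nM and 700 nM, which is an expected step of no change at the digits printed from compound 3 to compound 4 (within the scatter).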

Compound 4, half-maximal inhibitory concentration: 120 nM
For compound 4 the middle estimate is 3.1-fold (0.49 log units) above the measured one; the whole stated range lies above it.
By their numbers in this assay, from the lowest: compound 4; then compounds 1, 3 and 2 (each within the scatter of the next).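

Earlier exchanges of this side chain stayed within the scatter, but in this assay placing 4-hydroxy-5-(hydroxymethyl)oxolan-2-yl on the aromatic nitrogen gives a 3.1-fold lower number from compound 3 to compound 4 (0.49 log units; beyond the scatter) and, in place of 2,3-dihydroxypropyl, a 3.3-fold lower number from compound 2 to compound 4 (0.51 log units; beyond the scatter), both beyond the scatter. This position therefore does respond to the group it carries, and the response appears when the oxolane ring sits directly on the nitrogen rather than on a saturated chain carbon. Nothing available explains this step. The compounds shown leave open whether the direct ring attachment or the hydroxyl pattern matters more. They also leave open whether an amine in place of the 4-hydroxy group would keep the lower number.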